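This account rests on a few compounds, and the source may have more. Where it says the series, first, only, none or still open, it means among the compounds named here.

Of the compounds shown here, three built on one shared core have so far been measured in a functional assay on the whole organism (integument) for inhibition, with Chilo suppressalis as the target, read by scintillation counting, with a stated time of 72 h; on this read-out lower numbers stand for stronger inhibition and higher numbers for weaker inhibition. Compound 1 `O=C(Nc1nnc(-c2ccc(Cl)cc2)s1)c1c(Cl)cccc1Cl` gives 380 nM, compound 3 `O=C(Nc1nnc(-c2ccc(Cl)cc2)s1)c1ccccc1F` gives 724 nM, and compound 2 `COc1cccc(OC)c1C(=O)Nc1nnc(-c2ccc(Cl)cc2)s1` gives 58.9 nM. Among these three numbers compound 2 stands lowest, and its gaps to compound 1 and to compound 3 both lie beyond the usual scatter of repeated measurements, so compound 2 is the most potent of the three. None of the three measured compounds differs from another in a single place, so no single structural change can be read off directly from these numbers.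

Compound 4 `CCN(CC)c1ccc(-c2nnc(NC(=O)c3c(OC)cccc3OC)s2)cc1` keeps the whole of compound 2 except for one group: diethylamino in place of chloro on an aromatic carbon. The measured compounds vary only on the other side of the shared core, so nothing measured here speaks to a change at this position. Without such a guide, the step from compound 2 to compound 4 is expected to be modest, most likely a slight weakening, as a 2.0-fold higher number from compound 2 to compound 4 (0.31 log units; beyond the scatter). Compound 4 is therefore expected to give about 120 nM in this assay, with a plausible range from 30 nM to 500 nM.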

Compound 4, half-maximal inhibitory concentration: 741 nM
Beside the measured number, compound 4's estimate is 6.2-fold (0.79 log units) below it; the whole stated range lies below it.
By their numbers in this assay, from the lowest: compound 2; then compounds 1, 3 and 4 (each within the scatter of the next).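

In this assay, the position that carries the chloro group turns out to matter: diethylamino in its place gives a 13-fold higher number from compound 2 to compound 4 (1.10 log units; beyond the scatter), a large step well beyond the scatter. Within the data shown here, this is the first measured change on this side of the shared core, and it shows that the chloro group of compound 2 cannot be exchanged for diethylamino without a clear loss of inhibition, even with the rest of the molecule held constant. The change swaps 1 heavy atom for 5 heavy atoms and adds 1 hydrogen-bond acceptor, but no measurement shown here says why the number rises.

On these data alone, one step cannot separate the added carbon atoms from the added nitrogen, so it remains open whether a plain amino group, a methyl group or a short ethyl chain at this place would keep the number near that of compound 2. As far as these compounds go, it also remains open whether the same exchange would have a similar effect on compound 1 or compound 3, which carry different groups on the other side of the shared core.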